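This account rests on a few compounds, and the source may have more. Where it says the series, first, only, none or still open, it means among the compounds named here.

Compound 1 `COc1cc(/C=C/c2ccc(OCCCCC(=O)NO)cc2)cc(OC)c1` gives 3350 nM
Compound 2 `COc1cc(/C=C/c2ccc(OCCCCCC(=O)NO)cc2)cc(OC)c1` gives 4100 nM
Compound 3 `COc1cc(/C=C/c2ccc(OCCCCCCC(=O)NO)cc2)cc(OC)c1` gives 1070 nM

In a functional assay on HCT-116 cells (Homo sapiens) for cytotoxicity, read by MTT assay, with a stated time of 48 h (a higher number here means a weaker inhibitor, a lower number a stronger inhibitor), compound 3 stands lowest of the three, and its steps to both others lie beyond the scatter. Compound 4 `COc1cc(/C=C/c2ccc(OCCCCCCCC(=O)NO)cc2)cc(OC)c1` differs from compound 3 by one change ((hydroxycarbamoyl)methyl in place of hydroxycarbamoyl on a saturated chain carbon, six bonds along the chain from an oxygen on an aromatic ring). Four bonds along the chain the same replacement gave a 1.2-fold higher number from compound 1 to compound 2 (0.09 log units; within the scatter) and five bonds along it gave a 3.8-fold lower number from compound 2 to compound 3 (0.58 log units; beyond the scatter) while the two together gave a 3.1-fold lower number from compound 1 to compound 3 (0.50 log units; beyond the scatter) overall. One of these two single steps lies within the scatter and the other is modest, so they set no steady trend, and no step beyond the scatter is expected in this assay for this further replacement. The expected step is a 1.1-fold higher number from compound 3 to compound 4 (0.05 log units; within the scatter) on this estimate. Compound 4 is estimated at 1200 nM and expected to fall from 450 nM to 3200 nM on repeated measurement.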

Compound 4, half-maximal inhibitory concentration: 12600 nM
Compound 4: middle estimate off by 11-fold (1.02 log units), on the low side; measured number above the stated range.
By their numbers in this assay, from the lowest: compound 3; then compounds 1 and 2 (each within the scatter of the next); then compound 4.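

In this assay, lengthening the chain beyond compound 3 does not hold the number steady but gives a 12-fold higher number from compound 3 to compound 4 (1.07 log units; beyond the scatter), so the size and direction of this change depend on the position where it is made: the same change on two cores in this assay, a 1.2-fold higher number (0.09 log units; within the scatter) from compound 1 to compound 2 and a 12-fold higher number (1.07 log units; beyond the scatter) from compound 3 to compound 4, 9.6-fold (0.98 log units) apart, beyond the scatter of two such steps. The chain of compound 3 now stands out from both sides, with compound 4 also giving a 3.1-fold higher number from compound 2 to compound 4 (0.49 log units; beyond the scatter) and a 3.8-fold higher number from compound 1 to compound 4 (0.58 log units; beyond the scatter), and compound 3 has the lowest number of the four. Chain length therefore sets no single trend here.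

On these data alone, whether a longer chain would raise the number further remains open. So does the effect of a carboxylic acid in place of hydroxycarbamoyl on the chain of compound 3.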